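Removing a tertiary alcohol from a fused bicyclic core

The compounds below may be only part of what the source reports. "The series", "measured", "known", "first", "only" and "open" are said of these compounds alone.

Compound 1 `Cn1cc(-c2nc3c(-c4ccnc(OC5CC5)c4)cnn3cc2OCC(C)(C)O)cn1` gives 81% in an ADME assay on microsomes from liver (Rattus norvegicus) for metabolic stability, with a stated time of 60 min, tested at 1 uM; a lower number here means that less of the compound is left, a higher number that more of the compound is left.
Compound 2 `Cn1cc(-c2nc3c(-c4ccnc(OC5CC5)c4)cnn3cc2OCCCC(C)(C)O)cn1` gives 64% in this assay.
Compound 3 `COc1cc(-c2cnn3cc(OC)c(C(C)(C)O)nc23)ccn1` gives 92% in this assay.

Among these three, compound 3 stands highest in this assay; the gaps to compound 1 and to compound 2 both lie beyond the usual scatter of repeated measurements, so compound 3 is the most stable of the three shown. Compound 4 `COc1cnc2c(-c3ccnc(OC)c3)cnn2c1` has not yet been measured. It differs from compound 3 in a single spot: hydrogen in place of 1-hydroxy-1-methylethyl on an aromatic carbon. In plain terms, the 1-hydroxy-1-methylethyl group on the fused six-membered ring of compound 3 is gone, and a hydrogen atom sits there instead.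

Within the data shown here, only one measured step is available for comparison: a number 17 percentage points lower from compound 1 to compound 2 (beyond the scatter). That step exchanges one hydroxy-bearing chain for a longer one on an oxygen, so it touches a related group but is not the same kind of change as removing the alcohol altogether from a ring carbon. It offers only a loose guide. The expected outcome for compound 4 is therefore a step of a number 12 percentage points lower from compound 3 to compound 4 (beyond the scatter), a modest decrease or none beyond the scatter. The estimate for compound 4 in this assay is 80%, with a range from 58% to 95%.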

Compound 4, percent of the compound remaining: 10%
Beside the measured number, compound 4's estimate is 70 percentage points above it; measured number below the stated range.
By their numbers in this assay, from the lowest: compound 4; then compound 2; then compound 1; then compound 3.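

For this position, a number 82 percentage points lower from compound 3 to compound 4 (beyond the scatter) in this assay, so the choice between 1-hydroxy-1-methylethyl and hydrogen on this aromatic carbon, next to the ring nitrogen and ortho to a methoxy group, matters a great deal to how much compound is left. The earlier compounds shown here showed a smaller shift, a number 17 percentage points lower from compound 1 to compound 2 (beyond the scatter), and that change only altered a hydroxy-bearing chain on an oxygen, whereas this step removes the whole group from a ring carbon and is far larger. Nothing measured here explains why the loss of this group goes with such a large fall.

The compounds shown cannot separate the part played by the hydroxy group from that of the carbons around it, since a tert-butyl group, a methyl group or an amine on this same carbon would be needed to tell these apart. They also leave open whether a step of this size would hold with an ethoxy group or another group in place of the methoxy group on the six-membered ring.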